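The source may report more compounds than this note shows. Statements on the series, on what has been measured and on what is new or still open speak of the compounds shown alone.

The measured compounds:
Compound 1, `CC(C)(C)OC(=O)NCNC(=O)CN1CN(c2ccccc2)C2(CCN(C(=O)c3ccc(C4CCCCC4)cc3)CC2)C1=O`, gives 1700 nM in an assay on HEK293 cells for displacement of a labelled ligand from NPC1-like intracellular cholesterol transporter 1 (Homo sapiens); on this read-out lower numbers stand for stronger inhibition and higher numbers for weaker inhibition.
Compound 2, `CCOC(=O)C1CCN(C(=O)CN2CN(c3ccccc3)C3(CCN(C(=O)c4ccc(C(C)(C)C)cc4)CC3)C2=O)CC1`, gives 3100 nM in this assay.
Compound 3, `CC(C)(C)c1ccc(C(=O)N2CCC3(CC2)C(=O)N(CC(=O)NCCCCN)CN3c2ccccc2)cc1`, gives 14500 nM in this assay.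

Compound 1 has the lowest of the three numbers in this assay; compound 2 lies within the scatter of it, whereas compound 3 lies beyond it. Compound 4, `CS(=O)(=O)NCCCNC(=O)CN1CN(c2ccccc2)C2(CCN(C(=O)c3ccc(C4CCCCC4)cc3)CC2)C1=O`, has not yet been measured. It differs from compound 1 only in the tail on the shared core: 2-(methanesulfonamido)ethyl in place of (tert-butoxycarbonyl)amino on a saturated chain carbon bound to an amide-type nitrogen. Among the compounds with values here, the one measured step that touches this tail is a 4.7-fold higher number from compound 2 to compound 3 (0.67 log units; beyond the scatter), where (4-aminobutyl)amino replaced 4-(ethoxycarbonyl)piperidin-1-yl. The change from compound 1 to compound 4 instead keeps a group with no net charge, so a step no larger than the scatter is expected in this assay, if anything toward a higher number. Compound 4 is therefore expected to give 2500 nM, between 1000 nM and 6000 nM, a step of a 1.5-fold higher number from compound 1 to compound 4 (0.17 log units; within the scatter).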

Compound 4, half-maximal inhibitory concentration: 3800 nM
Beside the measured number, compound 4's estimate is 1.5-fold (0.18 log units) below it; the range from low to high includes it.
By their numbers in this assay, from the lowest: compounds 1, 2 and 4 (each within the scatter of the next, the first and the last beyond it); then compound 3.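

In this assay, a 2.2-fold higher number from compound 1 to compound 4 (0.35 log units; beyond the scatter) shows that the tail on the core of compound 1 can shift the number beyond the scatter, though only modestly. This happens even though the leaving and entering groups both have no ring, no net charge and the same counts of hydrogen-bond donors and acceptors. Nothing available explains the step. On these data alone, it remains open how a carboxylic acid or a terminal amine at this place on the core of compound 1 would read, and whether a longer chain carrying the methanesulfonamide would move the number further.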